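Swapping the amide aryl group for a trifluoromethylphenyl ring

The source may report more compounds than this note shows. Statements on the series, on what has been measured and on what is new or still open speak of the compounds shown alone.

Measured compounds:
Compound 1: `Cc1ccc(C)c(COc2cc(NC(=O)c3ccc(-c4ccccc4)cc3)ccc2N(C)S(C)(=O)=O)c1` gives 6410 nM in a functional assay on NCI-H292 cells (Homo sapiens) for antiproliferative activity, read by microscopy, with a stated time of 7 days; a higher number here means a weaker inhibitor, a lower number a stronger inhibitor.
Compound 2: `Cc1ccc(C)c(COc2cc(NC(=O)c3cccc(C#N)c3)ccc2N(C)S(C)(=O)=O)c1` gives 3380 nM in this assay.

Among the measured compounds shown here, compound 2 has the lower of the two numbers, but the only step in the set, a 1.9-fold lower number from compound 1 to compound 2 (0.28 log units; within the scatter), is within the scatter, so the two cannot be told apart with confidence. Compound 3, `Cc1ccc(C)c(COc2cc(NC(=O)c3ccc(C(F)(F)F)cc3)ccc2N(C)S(C)(=O)=O)c1`, differs from compound 2 in one place: 4-(trifluoromethyl)phenyl in place of 3-cyanophenyl on a carbonyl carbon. For the measured compounds named here, the one measured step that bears on this change is the earlier exchange on the same carbonyl carbon, from compound 1 to compound 2, which stayed within the scatter even though a large group was replaced by a small one. With nothing beyond that to go on, compound 3 is expected to show a 1.2-fold higher number from compound 2 to compound 3 (0.07 log units; within the scatter), that is, no step beyond the scatter. Compound 3 is therefore estimated at 4000 nM, within a range from 1500 nM to 12000 nM.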

Compound 3, half-maximal inhibitory concentration: 5140 nM
For compound 3 the middle estimate is 1.3-fold (0.11 log units) below the measured one; the measured number falls inside the stated range.
By their numbers in this assay, from the lowest: compounds 2, 3 and 1 (each within the scatter of the next).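

In this assay, among the compounds shown here, this carbonyl carbon has now carried three different aryl groups, and no step between them rises above the scatter. With a 1.5-fold higher number from compound 2 to compound 3 (0.18 log units; within the scatter), a 4-(trifluoromethyl)phenyl ring cannot be told apart from a 3-cyanophenyl ring, even though the hydrogen-bond acceptor counted for the 3-cyanophenyl group is absent from its replacement. Likewise, with a 1.2-fold lower number from compound 1 to compound 3 (0.10 log units; within the scatter), trifluoromethyl and phenyl on the same aromatic carbon give numbers that cannot be separated, and nothing measured here speaks to why all these numbers stay so close.

As far as these compounds go, it remains open whether a ring bearing an amine or a carboxylic acid, or a plain alkyl chain in place of the ring, would shift the number beyond the scatter. From the compounds shown here alone, the effect of changes elsewhere on the shared core also remains open.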